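This account rests on a few compounds, and the source may have more. Where it says the series, first, only, none or still open, it means among the compounds named here.

Measured so far:
Compound 1 `CC(C)[C@H](NC(=O)COc1cccc2ccccc12)C(=O)N[C@@H](CC(=O)O)C(=O)COc1ccccc1C(F)(F)F`: 17300 nM
Compound 2 `CC(C)[C@H](NC(=O)COc1cccc2ccccc12)C(=O)N[C@@H](CC(=O)O)C(=O)COc1ccc(Oc2ccccc2)cc1`: 19000 nM

In a functional assay with Homo sapiens as the target (a higher number here means a weaker inhibitor, a lower number a stronger inhibitor), compound 2 gives 19000 nM, and this lies within the scatter of compound 1 at 17300 nM, so the two cannot be told apart. Compound 3 `CC(C)[C@H](NC(=O)COc1cccc2ccccc12)C(=O)N[C@@H](CC(=O)O)C(=O)COc1ccc([N+](=O)[O-])cc1` has not yet been measured. It carries nitro in place of phenoxy on an aromatic carbon, para to a large group (nitro in place of phenoxy on an aromatic carbon). Going by the values given here, no measured pair differs in one place only, so the guide is thin, and no change beyond the scatter is expected in this assay. The expected change is small, a 1.2-fold lower number from compound 2 to compound 3 (0.07 log units; within the scatter). For compound 3 the estimated value is 16000 nM, with an expected range of 6000 nM to 40000 nM.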

Compound 3, half-maximal inhibitory concentration: 22800 nM
Compound 3: the middle estimate sits 1.4-fold (0.15 log units) below what was measured; low and high end bracket the measured number.
By their numbers in this assay, from the lowest: compounds 1, 2 and 3 (each within the scatter of the next).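

In this assay the change to nitro, a smaller group without a ring, gives a 1.2-fold higher number from compound 2 to compound 3 (0.08 log units; within the scatter) and so cannot be told apart from phenoxy on this aromatic carbon. Exchanging the whole 2-(trifluoromethyl)phenyl for 4-nitrophenyl gives a 1.3-fold higher number from compound 1 to compound 3 (0.12 log units; within the scatter) as well, so these different groups leave all three compounds indistinguishable in this read-out. No measurement at hand explains this.

Going by these compounds, whether an amine or a methoxy group on this aromatic carbon would shift the number remains open. So does whether any change here can move it beyond the scatter.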